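A few compounds are considered here, and "the series" means these few. Any claim that something is new, unique, unknown or untested is made for them only; others in the source may bear on it.

Measured compounds:
Compound 1 `Clc1ccccc1CSc1nnc(-c2ccncc2)n1-c1ccccc1`, in a functional assay on MCF7 cells (Homo sapiens) for inhibition, read by MTT assay, with a stated time of 48 h (on this read-out lower numbers stand for stronger inhibition and higher numbers for weaker inhibition), compound 1 gives 18100 nM.
Compound 2 `Fc1cccc(F)c1CSc1nnc(-c2ccncc2)n1-c1ccccc1`; in this assay compound 2 reaches only a limit, > 50000 nM.

Compound 1 holds the only number shown in this assay; the one other value is a limit of the assay. Compound 3 `c1ccc(CSc2nnc(-c3ccncc3)n2-c2ccccc2)cc1` is the unmeasured partner of compound 1, differing by hydrogen in place of chloro on an aromatic carbon. Among the compounds with values here, one measured step bears on this change, since it also alters the same chlorophenyl: an at least 2.7-fold higher number from compound 1 to compound 2 (0.44 log units; beyond the scatter), a step that ran into (the limit of > 50000 nM in this assay, at which 1 of the 2 values shown sits). That change put two fluorines in while taking the chlorine out, so it is not the same as removing the chlorine alone, but it points toward a higher number once the chloro is gone. The step is therefore expected to be a 1.8-fold higher number from compound 1 to compound 3 (0.25 log units; within the scatter), a modest weakening. For compound 3 in this assay the estimate is 32000 nM, with a range from 12000 nM to 80000 nM.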

Compound 3, half-maximal inhibitory concentration: 22400 nM
The estimate for compound 3 lay 1.4-fold (0.15 log units) above the measured number; low and high end bracket the measured number.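

In this assay, removing the chloro alone gives a 1.2-fold higher number from compound 1 to compound 3 (0.09 log units; within the scatter), so this single change leaves the read-out indistinguishable from that of compound 1, and the chloro is not required for the inhibition seen here. The plain phenyl also gives the 2,6-difluorophenyl change a direct reference: an at least 2.2-fold lower number from compound 2 to compound 3 (0.34 log units; beyond the scatter), which places the weaker result with the two fluorines rather than with the absence of chlorine. The value of compound 2 is a limit of the assay, so this step has no exact size: the limit of > 50000 nM in this assay, at which 1 of the 3 values shown sits.

Going by these compounds, whether a methoxy group or an amine on this aromatic carbon would shift the number beyond the scatter remains open. Also open, on these data alone, is how a longer chain in place of the benzyl group's saturated carbon would read.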